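Glucagon receptor binding: aryl swap on the spiro-imidazolone core

This account rests on a few compounds, and the source may have more. Where it says the series, first, only, none or still open, it means among the compounds named here.

Measured compounds:
compound 1 `C[C@H](c1ccc(C(=O)NCCC(=O)O)cc1)N1C(=O)C(c2cccc(Cl)c2)=N[C@]12CC[C@@H](C(C)(C)C)CC2`: 130 nM
compound 2 `CC(C)(C)CC[C@H](c1ccc(C(=O)NCc2nn[nH]n2)cc1)N1C(=O)C(c2cncc(Cl)c2)=N[C@]12CC[C@@H](C(C)(C)C)CC2`: 38 nM

In an assay on CHO cells for displacement of a labelled ligand from Glucagon receptor (Homo sapiens), read by scintillation counting, with a stated time of 60 min (a higher number here means a weaker inhibitor, a lower number a stronger inhibitor), compound 1 gives 130 nM and compound 2 gives 38 nM. Compound 2 stands at the lowest of the two numbers, and its separation from compound 1 lies beyond the usual scatter; the two compounds differ at several places at once, so no single change can be tied to that gap.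

Compound 3 `CC(C)(C)CC[C@H](c1ccc(C(=O)NCc2nn[nH]n2)cc1)N1C(=O)C(c2cnccc2C(F)(F)F)=N[C@]12CC[C@@H](C(C)(C)C)CC2` has not been measured. It differs from compound 2 in one place: 4-(trifluoromethyl)pyridin-3-yl in place of 5-chloropyridin-3-yl on a carbon with a double bond to nitrogen — 4-(trifluoromethyl)pyridin-3-yl in place of 5-chloropyridin-3-yl on a carbon with a double bond to nitrogen. Among the compounds with values here, no measured pair shows the effect of this swap, so the expected step in this assay is small, with a slight lean toward a higher number; the expected step from compound 2 to compound 3 is a 1.6-fold higher number from compound 2 to compound 3 (0.20 log units; within the scatter). Compound 3 is estimated at 60 nM, within a range of 20 nM to 200 nM.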

Compound 3, half-maximal inhibitory concentration: 22 nM
The estimate for compound 3 lay 2.7-fold (0.44 log units) above the measured number; the measured number falls inside the stated range.
By their numbers in this assay, from the lowest: compounds 3 and 2 (each within the scatter of the next); then compound 1.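

On the carbon with a double bond to nitrogen of the shared core, 4-(trifluoromethyl)pyridin-3-yl in place of 5-chloropyridin-3-yl gives a 1.7-fold lower number from compound 2 to compound 3 (0.24 log units; within the scatter) in this assay. Within the data shown here, this is the only single-place step so far, and it shows that this position accepts the entering group, with 10 heavy atoms in place of 7, with no difference in binding that stands clear of the usual scatter. Nothing measured here accounts for this result.

The compounds shown leave open how this position responds to a pyridine bearing a nitrile or an amine instead of chlorine or trifluoromethyl. They also leave open whether the same swap would read alike on a compound carrying the carboxylic acid side chain of compound 1.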